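This account rests on a few compounds, and the source may have more. Where it says the series, first, only, none or still open, it means among the compounds named here.

Measured compounds:
Compound 1, `Nc1ccc(/C=C2\SC(=O)N(Cc3cccc(F)c3)C2=O)cc1`, gives 250000 nM in a functional assay on HeLa cells (Homo sapiens) for cytotoxicity, read by cell counting, with a stated time of 4 days; on this read-out higher numbers stand for weaker inhibition and lower numbers for stronger inhibition.
Compound 2, `Cc1ccc(CN2C(=O)S/C(=C\c3ccc(N)cc3)C2=O)cc1`, gives in this assay only the limit > 250000 nM, which is a boundary of the assay and not a number.

So compound 2 stands at the limit of this assay, and its true value is open (the limit of > 250000 nM in this assay, at which 1 of the 2 values shown sits). Compound 3, `CN1C(=O)S/C(=C\c2ccc(N)cc2)C1=O`, has not been measured in this assay. Its difference from compound 2 is hydrogen in place of 4-methylphenyl on a saturated chain carbon bound to an amide-type nitrogen in a ring; the shared core is kept, and only the group on the saturated chain carbon bound to the amide-type nitrogen in the ring is taken away. For the measured compounds named here, the only measured step, a number no lower from compound 1 to compound 2 (the limit leaves the size open), exchanges one aromatic group for another at that same place, and because it ends at the limit of > 250000 nM in this assay, at which 1 of the 2 values shown sits, its size cannot be read. Going by the values given here, no measured step shows the full removal of such a group. Both measured compounds sit at or beyond the top of the range, so no move beyond the scatter is expected in this assay for compound 3, and the expected step is a number no higher from compound 2 to compound 3 (the limit leaves the size open). Compound 3 is therefore estimated at about 250000 nM, with a range from 100000 nM to 600000 nM.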

Compound 3, half-maximal inhibitory concentration: 97000 nM
Compound 3: the middle estimate sits 2.6-fold (0.41 log units) above what was measured; measured number below the stated range.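

For the compounds shown here, until now, the only change seen on the saturated chain carbon bound to an amide-type nitrogen in a ring was one aromatic group exchanged for another. Here the aromatic group leaves altogether, and in this assay hydrogen in place of 4-methylphenyl gives an at least 2.5-fold lower number from compound 2 to compound 3 (0.41 log units; beyond the scatter), while hydrogen in place of 3-fluorophenyl gives a 2.6-fold lower number from compound 1 to compound 3 (0.41 log units; beyond the scatter), so this place does affect the read-out, and both aromatic groups shown go with weaker inhibition than compound 3 has. The first of these steps has no exact size, and the step between the two aromatic compounds cannot be read, because compound 2 carries only a limit: the limit of > 250000 nM in this assay, at which 1 of the 3 values shown sits.

As far as these compounds go, it remains open whether a longer chain such as butyl at this place would stay close to compound 3 or move towards compound 1, and what an amine or a carboxylic acid at the end of such a chain would do. From the compounds shown here alone, it also remains open whether any group here can bring the number far below the range of these three compounds.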